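Trimming an aryl ring from the core: compound 4 expected

A few compounds are considered here, and "the series" means these few. Any claim that something is new, unique, unknown or untested is made for them only; others in the source may bear on it.

Measured so far:
Compound 1 `Nc1ccc(/C=C2\SC(=O)N(Cc3ccc(Cl)cc3)C2=O)cc1`: 87000 nM
Compound 2 `CC(C)(C)c1ccc(CN2C(=O)S/C(=C\c3cccc(N)c3)C2=O)cc1`: 165000 nM
Compound 3 `Nc1cccc(/C=C2\SC(=O)N(Cc3ccc(F)cc3)C2=O)c1`: 87000 nM

Three analogues sharing one core have been tested in a functional assay on CCRF-CEM cells (Homo sapiens) for cytotoxicity, read by cell counting, with a stated time of 3 days; on this read-out lower numbers stand for stronger inhibition and higher numbers for weaker inhibition. Compound 1 gives 87000 nM, which is level with compound 3 at the digits reported and, together with it, the lowest of the three numbers; compound 2 lies furthest away, and the gap is within the scatter. For the measured compounds named here, the only single-point step among the measured compounds, a 1.9-fold lower number from compound 2 to compound 3 (0.28 log units; within the scatter), concerns a substituent on the aryl ring attached through the chain carbon and stays within the scatter.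

Compound 4 `CCN1C(=O)S/C(=C\c2ccc(N)cc2)C1=O` has not yet been measured. It differs from compound 1 in one place: methyl in place of 4-chlorophenyl on a saturated chain carbon bound to an amide-type nitrogen in a ring. Going by the values given here, no measured step bears directly on this change, since the one step available kept the ring and only swapped its substituent; removing the ring altogether is a larger alteration, and its direction cannot be read from the present data. Given that all three measured numbers sit close together, compound 4 is expected to land near them, with a modest drift toward a higher number in this assay, described by a 1.7-fold higher number from compound 1 to compound 4 (0.24 log units; within the scatter). The estimated value for compound 4 is 150000 nM, within a range from 60000 nM to 400000 nM.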

Compound 4, half-maximal inhibitory concentration: 91000 nM
Estimate against measurement, compound 4: 1.6-fold (0.22 log units) above; low and high end bracket the measured number.
By their numbers in this assay, from the lowest: compounds 1, 3, 4 and 2 (each within the scatter of the next).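

In this assay, methyl in place of 4-chlorophenyl on a saturated chain carbon bound to an amide-type nitrogen in a ring gives a 1.0-fold higher number from compound 1 to compound 4 (0.02 log units; within the scatter). The earlier compounds shown here changed only the substituent on this aromatic ring, whereas this pair shows that the entire ring, with its 7 heavy atoms, can give way to a group of 1 heavy atom without the number leaving the scatter. No measurement shown here accounts for this result.

The compounds shown contain no group at this place that moves the number beyond the scatter, so it remains open whether any substituent there can do so. A longer chain, an amine or a carboxylic acid in place of the methyl would test this directly.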